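A few compounds are considered here, and "the series" means these few. Any claim that something is new, unique, unknown or untested is made for them only; others in the source may bear on it.

Of the compounds shown here, three have numbers so far in a functional assay on CWR22R cells (Homo sapiens) for antiproliferative activity, read by propidium iodide staining, with a stated time of 96 h; on this read-out higher numbers stand for weaker inhibition and lower numbers for stronger inhibition. Compound 1 (`CC(O)(COc1ccc(C#N)cc1C(F)(F)F)C(=O)Nc1cccc(S(F)(F)(F)(F)F)c1`) gives 18300 nM, compound 2 (`CC(O)(CS(=O)(=O)c1cccc(S(F)(F)(F)(F)F)c1)C(=O)Nc1ccc([N+](=O)[O-])c(C(F)(F)F)c1`) gives 14800 nM, and compound 3 (`CC(O)(CS(=O)(=O)c1cccc(S(F)(F)(F)(F)F)c1)C(=O)Nc1cccc(S(F)(F)(F)(F)F)c1`) gives 15400 nM. Compound 3 therefore sits within the usual scatter of both others, and the three values cannot be told apart. Compound 4 (`CC(O)(CS(=O)(=O)c1cccc(OC(F)(F)F)c1)C(=O)Nc1cccc(S(F)(F)(F)(F)F)c1`) differs from compound 3 in one place, on an aromatic carbon: a group of 5 heavy atoms (1 carbon, 1 oxygen, 3 fluorine; no ring) in place of a group of 6 heavy atoms (5 fluorine, 1 sulfur; no ring), on an aromatic carbon. The incoming group is trifluoromethoxy. Within the data shown here, no measured pair shows this kind of swap, so the only guide is the narrow spread of values so far, and no step beyond the scatter is expected in this assay. The expected change is a 1.0-fold lower number from compound 3 to compound 4 (0.01 log units; within the scatter). For compound 4 the estimated value is 15000 nM, with a range of 8000 nM to 28000 nM.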

Compound 4, half-maximal inhibitory concentration: 20100 nM
For compound 4 the middle estimate is 1.3-fold (0.13 log units) below the measured one; the range from low to high includes it.
By their numbers in this assay, from the lowest: compounds 2, 3, 1 and 4 (each within the scatter of the next).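

Replacing the group of sulfur and five fluorines on this aromatic carbon with trifluoromethoxy gives, in this assay, a 1.3-fold higher number from compound 3 to compound 4 (0.12 log units; within the scatter). Among these compounds, this is the first comparison here of two compounds differing in one place, and it shows that compound 3 and compound 4 cannot be told apart, so the two groups are interchangeable at this position on this read-out. Nothing available speaks to the reason for this result. Going by these compounds, whether an amine or a carboxylic acid at this position would separate from these values remains open, as does the effect of any other group there.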